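Ring Swap on the Saturated Ring of Compound 1

The source may report more compounds than this note shows. Statements on the series, on what has been measured and on what is new or still open speak of the compounds shown alone.

Compound 1 `Cc1cccc(NC(=O)CN2CCC(c3nccs3)CC2)c1`: 1 nM
Compound 2 `O=C(NCN1CCC(c2cccc[n+]2[O-])CC1)c1cc(Cl)cc(Cl)c1`: 45 nM
Compound 3 `CC(C)Oc1cccc(NC(=O)CN2CCC(c3cccc[n+]3[O-])CC2)c1`: 555 nM

Of the compounds shown here, three have been measured in a functional assay on HEK293 cells for agonist activity at D(4) dopamine receptor (Homo sapiens), read by FLIPR; a higher number here means that more compound is needed for the effect, a lower number that less compound is needed. Compound 1 gives 1 nM, the lowest of the three numbers, so it needs the least compound for the effect. Compound 2 gives 45 nM, a higher number that lies beyond the scatter of repeat measurements. Compound 3 gives 555 nM, the highest of the three and furthest from compound 1. Among the measured compounds shown here, no pair of these three differs in only one place, so none of the gaps can be tied to a single structural change.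

Compound 4 `Cc1cccc(NC(=O)CN2CCC(c3ccccc3F)CC2)c1` has not yet been measured in this assay. It is built from compound 1 by one change: 2-fluorophenyl in place of 1,3-thiazol-2-yl on a saturated ring carbon. For the measured compounds named here, nothing among the measured compounds shows what this swap does, so the expectation rests on compound 1 alone, whose value of 1 nM sets the starting point. A modest rise in the number is expected, with the step from compound 1 to compound 4 estimated at a 3.0-fold higher number from compound 1 to compound 4 (0.48 log units; beyond the scatter), a change at the edge of the usual scatter. Compound 4 is therefore expected to give about 3 nM in this assay, with a likely range from 0.5 nM to 20 nM.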

Compound 4, half-maximal effective concentration: 1 nM
Estimate against measurement, compound 4: 3.0-fold (0.48 log units) above; the range from low to high includes it.
By their numbers in this assay, from the lowest: compounds 1 and 4 (each within the scatter of the next); then compound 2; then compound 3.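

In this assay, putting 2-fluorophenyl in place of 1,3-thiazol-2-yl on a saturated ring carbon gives no change at the digits printed from compound 1 to compound 4 (within the scatter). Among the compounds shown here, this is the first single-change step seen at this position, three ring bonds from the ring nitrogen, and it shows that a five-membered aromatic ring with 2 hetero atoms and 2 hydrogen-bond acceptors can give way to a six-membered aromatic ring of carbon only, with 0 hydrogen-bond acceptors, without the number moving outside the usual scatter for this pair. No measurement shown here explains why these two groups read alike.

The compounds shown do not reveal whether the fluorine matters, since plain phenyl is not among them, nor how this position would respond to a saturated group such as cyclohexyl or to a ring bearing an amine. Compound 2 and compound 3 each differ from compound 1 and from compound 4 in more than one place, so their gaps cannot be read as the effect of any single change.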